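This account rests on a few compounds, and the source may have more. Where it says the series, first, only, none or still open, it means among the compounds named here.

Compound 1 `O=C(O)CC(NS(=O)(=O)c1cccc([N+](=O)[O-])c1)c1ccccc1`: > 100000 nM (a limit)
Compound 2 `O=C(O)CC(NS(=O)(=O)c1ccccc1)c1ccc(Cl)cc1Cl`: 57800 nM
Compound 3 `O=C(O)CC(NS(=O)(=O)c1ccccc1Br)c1ccc(Cl)cc1Cl`: > 100000 nM (a limit)

For the measured compounds named here, in a functional assay on MDA-MB-231 cells (Homo sapiens) for antiproliferative activity, read by MTT assay, with a stated time of 24 h (on this read-out higher numbers stand for weaker inhibition and lower numbers for stronger inhibition), compound 2 gives 57800 nM, the only real number in this small set. Around it stands (the limit of > 100000 nM in this assay, at which 2 of the 3 values shown sit).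

Compound 4 `O=C(O)CC(NS(=O)(=O)c1cccc([N+](=O)[O-])c1)c1ccc(Cl)cc1Cl` has not yet been measured. It differs from compound 2 by nitro in place of hydrogen on an aromatic carbon.

Going by the values given here, the one measured step of a similar kind adds a bromo group instead: an at least 1.7-fold higher number from compound 2 to compound 3 (0.23 log units; that floor lies within the scatter). On these data alone, that step gives only a floor, so its true size is unknown. Compound 1 also carries a nitro group, and its > 100000 nM is a limit. Neither result offers grounds to expect a gain in strength.

The expected change is small and towards weaker inhibition: a 1.3-fold higher number from compound 2 to compound 4 (0.11 log units; within the scatter). Compound 4 is estimated at 75000 nM, with an expected range from 30000 nM to 100000 nM. A reading of compound 4 at the limit would be no surprise.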

Compound 4, half-maximal inhibitory concentration: 77800 nM
Beside the measured number, compound 4's estimate is 1.0-fold (0.02 log units) below it, within the range that was stated.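

In this assay, nitro on this aromatic carbon, meta to a large group, gives a real number rather than a limit, and the step is a 1.3-fold higher number from compound 2 to compound 4 (0.13 log units; within the scatter), so this change leaves the reading within the usual scatter. With nitro kept in place, 2,4-dichlorophenyl in place of phenyl gives an at least 1.2-fold lower number from compound 1 to compound 4 (0.10 log units; that floor lies within the scatter), and that floor does not establish a real difference. The true size of this step stays unknown because compound 1 gives only a limit: the limit of > 100000 nM in this assay, at which 2 of the 4 values shown sit.

On these data alone, whether an amine or a methoxy group on the same aromatic carbon would move the number beyond the scatter remains open. So does the effect of a longer chain between the carboxylic acid and the carbon that bears the sulfonamide nitrogen.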